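Relocating the chloro substituent on the benzoyl group

A few compounds are considered here, and "the series" means these few. Any claim that something is new, unique, unknown or untested is made for them only; others in the source may bear on it.

Compound 1 `COc1cc2ncnc(NNC(=S)NC(=O)c3ccccc3C)c2cc1OC` gives 21500 nM in a functional assay on GLC82 cells (Homo sapiens) for cytotoxicity, read by MTT assay, with a stated time of 72 h; a higher number here means a weaker inhibitor, a lower number a stronger inhibitor. Compound 2 `COc1cc2ncnc(NNC(=S)NC(=O)c3ccccc3)c2cc1OC` gives 6550 nM. Compound 3 `COc1cc2ncnc(NNC(=S)NC(=O)c3cccc(Cl)c3)c2cc1OC` gives 8370 nM.

Within this small set, compound 3 stands second highest of the three numbers. Its nearest neighbour is compound 2, whose value lies within the scatter of it, as the step of a 1.3-fold higher number from compound 2 to compound 3 (0.11 log units; within the scatter) shows; the gap to compound 1 is the larger one, a 2.6-fold lower number from compound 1 to compound 3 (0.41 log units; beyond the scatter), which runs beyond the scatter. Among the compounds with values here, the only other step, a 3.3-fold lower number from compound 1 to compound 2 (0.52 log units; beyond the scatter), is likewise modest.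

Compound 4 `COc1cc2ncnc(NNC(=S)NC(=O)c3ccc(Cl)cc3)c2cc1OC` is the next structure to be tested in this assay. It differs from compound 3 in a single place: 4-chlorophenyl in place of 3-chlorophenyl on a carbonyl carbon.

Within the data shown here, no measured step moves a substituent from one position of the phenyl ring to another, so the bearing of the data is indirect. The closest relevant step is a 1.3-fold higher number from compound 2 to compound 3 (0.11 log units; within the scatter), where introducing a chloro at all changed the number by an amount within the scatter. Since the chloro is kept and only relocated, a step of similar size, or none beyond the scatter, is expected from compound 3 to compound 4: a 1.0-fold lower number from compound 3 to compound 4 (0.02 log units; within the scatter). Compound 4 is therefore estimated at 8000 nM, with a range from 4000 nM to 16000 nM.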

Compound 4, half-maximal inhibitory concentration: 9620 nM
Estimate against measurement, compound 4: 1.2-fold (0.08 log units) below; the range from low to high includes it.
By their numbers in this assay, from the lowest: compounds 2, 3 and 4 (each within the scatter of the next); then compound 1.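

Relocating the chloro, from the 3-chlorophenyl to the 4-chlorophenyl group on the carbonyl carbon, gives the first direct reading of substituent position in this assay (a step of a 1.1-fold higher number from compound 3 to compound 4 (0.06 log units; within the scatter)), and it does not separate the two compounds. Compared with hydrogen, the chloro in its new place also leaves the number within the scatter (a 1.5-fold higher number from compound 2 to compound 4 (0.17 log units; within the scatter)), so among the compounds carrying hydrogen or chloro on this ring, neither chloro placement stands apart, while the 2-methylphenyl group remains apart from the 4-chlorophenyl group by a modest margin (a 2.2-fold lower number from compound 1 to compound 4 (0.35 log units; beyond the scatter)). Nothing measured alongside these cell numbers accounts for any of these steps.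

On these data alone, it remains open whether a 2-chlorophenyl group on the same carbonyl carbon would read like compound 1 or like compound 4, which would help show whether the methyl group or its place goes with the higher number of compound 1. As far as these compounds go, it is equally open how a 4-methylphenyl, 4-aminophenyl or 4-carboxyphenyl group would compare with the 4-chlorophenyl group at this position.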